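From compound 2 to compound 4: working notes

A few compounds are considered here, and "the series" means these few. Any claim that something is new, unique, unknown or untested is made for them only; others in the source may bear on it.

In a functional assay on DU-145 cells (Homo sapiens) for inhibition, read by trypan blue exclusion, with a stated time of 96 h (a lower number here means a stronger inhibitor of growth, a higher number a weaker inhibitor of growth), compound 1 (`O=C(/C(=C\c1ccc(O)cc1O)Sc1ccc(Br)cc1)c1ccc(Cl)cc1`) gives 50000 nM and compound 2 (`CSc1ccc(/C=C(\C(=O)c2ccc(Br)cc2)S(=O)(=O)Cc2ccc(F)cc2)cc1`) gives 50000 nM with no difference at the digits shown. Compound 3 (`O=C(/C(=C\c1ccc(O)c([N+](=O)[O-])c1)SCc1ccc(Br)cc1)c1ccc(Cl)cc1Cl`) gives 10000 nM and this lower number lies beyond the scatter from compound 2. Compound 2 therefore shares the highest number of the three with compound 1. Compound 4 (`Cc1ccc(/C=C(\C(=O)c2ccc(Br)cc2)S(=O)(=O)Cc2ccc(F)cc2)s1`) has 5-methylthiophen-2-yl in place of 4-(methylsulfanyl)phenyl on a double-bonded chain carbon bound to a double-bonded chain carbon. Among the measured compounds shown here, no measured pair isolates a single change. The expected step (a 1.7-fold lower number from compound 2 to compound 4 (0.22 log units; within the scatter)) is small, towards a lower number and not beyond the scatter. For compound 4 the estimate is 30000 nM with an expected range from 9000 nM to 60000 nM (both estimated).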

Compound 4, concentration for 50% growth inhibition: 1000 nM
Estimate against measurement, compound 4: 30-fold (1.48 log units) above, and the stated range ends above it.
By their numbers in this assay, from the lowest: compound 4; then compound 3; then compounds 1 and 2 (each within the scatter of the next).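

In this assay, 5-methylthiophen-2-yl in place of 4-(methylsulfanyl)phenyl on a double-bonded chain carbon bound to a double-bonded chain carbon gives a 50-fold lower number from compound 2 to compound 4 (1.70 log units; beyond the scatter). Among the compounds shown here, this is the only step that can be read at a single place, and it shows that this position alone can move the growth-inhibition number by a large margin while the rest of compound 2 stays the same. Nothing on hand accounts for the size of this step.

The compounds shown do not separate the ring change from the methyl group. As far as these compounds go, whether a plain thiophen-2-yl or a thiophene carrying an amine would keep this lower number remains open.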